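The compounds below may be only part of what the source reports. "The series", "measured", "known", "first", "only" and "open" are said of these compounds alone.

Series notes, amide variation on the shared core. Compound 1 `CN(C(=O)C(C)(C)C)c1ccc2[nH]c(-c3n[nH]c4ccccc34)cc2n1` gives, in a functional assay on SMMC-7721 cells (Homo sapiens) for antiproliferative activity, read by MTT assay, with a stated time of 72 h (a higher number here means a weaker inhibitor, a lower number a stronger inhibitor), a value of 22200 nM. Compound 2 `CN(C(=O)CCc1ccccc1)c1ccc2[nH]c(-c3n[nH]c4ccccc34)cc2n1` gives 20900 nM in this assay, and compound 3 `COc1cccc(C(=O)N(C)c2ccc3[nH]c(-c4n[nH]c5ccccc45)cc3n2)c1` gives 22000 nM. The three acyl variants so far move the number hardly at all: a 1.1-fold lower number from compound 1 to compound 2 (0.03 log units; within the scatter), a 1.0-fold lower number from compound 1 to compound 3 (0.00 log units; within the scatter) and a 1.1-fold higher number from compound 2 to compound 3 (0.02 log units; within the scatter). Among the measured compounds shown here, compound 3 therefore sits with compound 1 and compound 2 inside one band, with no step to either that exceeds the scatter.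

Compound 4 `CN(c1ccc2[nH]c(-c3n[nH]c4ccccc34)cc2n1)S(=O)(=O)c1ccc(Cl)cc1` carries (4-chlorophenyl)sulfonyl in place of (3-methoxyphenyl)carbonyl on a nitrogen on an aromatic ring. For the measured compounds named here, none of the measured steps exchanges the carbonyl itself, so the recorded steps bear on this change only indirectly, and all of them were within the scatter. With no evidence of movement in the series, the step from compound 3 to compound 4 is expected to be no change at the digits printed from compound 3 to compound 4 (within the scatter) in this assay. The estimate for compound 4 in this assay is 22000 nM, with a range from 8000 nM to 60000 nM.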

Compound 4, half-maximal inhibitory concentration: 12700 nM
Compound 4: the middle estimate sits 1.7-fold (0.24 log units) above what was measured; the range from low to high includes it.
By their numbers in this assay, from the lowest: compounds 4, 2, 3 and 1 (each within the scatter of the next).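

In this assay, the position on the nitrogen on an aromatic ring accepts a sulfonyl as well as a carbonyl without a step beyond the scatter: a 1.7-fold lower number from compound 3 to compound 4 (0.24 log units; within the scatter) and a 1.6-fold lower number from compound 2 to compound 4 (0.22 log units; within the scatter) and a 1.7-fold lower number from compound 1 to compound 4 (0.24 log units; within the scatter). The single band seen across the acyl variants therefore now extends to a change of the atom that links the group to this nitrogen, and not only to a change of the group on the carbonyl carbon. Nothing available explains this result.

The carbonyl and the aryl group change together in these steps, so the compounds shown cannot separate the sulfonyl from the 4-chlorophenyl. Also open, going by these compounds, is whether a carboxylic acid, an amine-bearing chain or a plain hydrogen on this nitrogen would stay within the same band.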